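Replacing a cyclopropyl carbamate substituent with a tert-butylsulfanyl group

The source may hold more compounds than are shown below. What is called first, only, known or untested is meant among the compounds shown, and "the series" means these compounds.

Three compounds sharing one core have been examined in a functional assay on isolated protein for inhibition of Glucose-dependent insulinotropic receptor (Homo sapiens), read by HTRF and cAMP accumulation; on this read-out higher numbers stand for an effect only at larger amounts of compound and lower numbers for an effect already at smaller amounts. Compound 1 `Cc1nc(S(C)(=O)=O)ccc1Oc1ncnc(OC2CCN(C(=O)OC(C)C)CC2)c1F` gives 21 nM. Compound 2 `Cc1nc(S(C)(=O)=O)ccc1Oc1ncnc(OC2CCN(C(=O)O[C@@H](C)C(F)(F)F)CC2)c1F` gives 9.86 nM, and compound 3 `CCC1(OC(=O)N2CCC(Oc3ncnc(Oc4ccc(S(C)(=O)=O)nc4C)c3F)CC2)CC1` gives 22 nM. Compound 3 therefore carries the highest of the three numbers, though its distance from compound 1 is within the scatter a 1.0-fold higher number from compound 1 to compound 3 (0.02 log units; within the scatter), while its distance from compound 2 is beyond it a 2.2-fold higher number from compound 2 to compound 3 (0.35 log units; beyond the scatter).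

Compound 4 `Cc1nc(S(C)(=O)=O)ccc1Oc1ncnc(OC2CCN(C(=O)SC(C)(C)C)CC2)c1F` differs from compound 3 by the change (a group of 5 heavy atoms (4 carbon, 1 sulfur; no ring) in place of a group of 6 heavy atoms (5 carbon, 1 oxygen; one three-membered non-aromatic ring of carbon only), on a carbonyl carbon). The measured steps that bear on this position are a 2.1-fold lower number from compound 1 to compound 2 (0.33 log units; beyond the scatter) and a 1.0-fold higher number from compound 1 to compound 3 (0.02 log units; within the scatter): both stay at or near the scatter. Among the compounds with values here, the change into compound 4 touches the same carbonyl carbon, but no measured step exchanges the oxygen-bound group for a sulfur-bound one, so the expectation rests on the modest size of those steps alone. Compound 4 is therefore expected to show a step of about a 1.1-fold higher number from compound 3 to compound 4 (0.06 log units; within the scatter) in this assay, not beyond the scatter. Compound 4 is estimated at 25 nM, within a range from 8 nM to 75 nM.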

Compound 4, half-maximal effective concentration: 4.83 nM
For compound 4 the middle estimate is 5.2-fold (0.71 log units) above the measured one, and the stated range ends above it.
By their numbers in this assay, from the lowest: compound 4; then compound 2; then compounds 1 and 3 (each within the scatter of the next).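

In this assay, the (tert-butyl)sulfanyl group on the carbonyl carbon gives a number beyond the scatter against each of the three oxygen-bound groups (a 4.6-fold lower number from compound 3 to compound 4 (0.66 log units; beyond the scatter)) and (a 4.3-fold lower number from compound 1 to compound 4 (0.64 log units; beyond the scatter)) and (a 2.0-fold lower number from compound 2 to compound 4 (0.31 log units; beyond the scatter)). The earlier exchanges at this place stayed at or near the scatter, so compound 4 shows that this place can carry a larger step than they revealed, and it holds the lowest number of the four. Nothing at hand accounts for this step.

The compounds shown change the sulfur and the tert-butyl group together, so tert-butoxy on the same carbonyl carbon would be needed to tell which of the two goes with the step. On these data alone, how a tert-butylamino group or a smaller sulfur-bound group such as isopropylsulfanyl would read at this place also stays open.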